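The source may report more compounds than this note shows. Statements on the series, on what has been measured and on what is new or still open speak of the compounds shown alone.

Measured so far in a functional assay, read by spectrophotometry, with a stated time of 30 min; on this read-out higher numbers stand for weaker inhibition and lower numbers for stronger inhibition:
Compound 1, `COc1ccc(C(=O)ON=C2CC(c3ccc(O)c(OC)c3)N(C)C(c3ccc(O)c(OC)c3)C2)cc1`: 33000 nM
Compound 2, `COc1cc(C2CC(=NOC(=O)c3ccc(Cl)cc3)CC(c3ccc(O)c(OC)c3)N2C)ccc1O`: 112000 nM
Compound 3, `COc1cc(C2CC(=NOC(=O)c3cccc(O)c3)CC(c3ccc(O)c(OC)c3)N2C)ccc1O`: 16500 nM

Among these three numbers compound 1 stands second highest. Its nearest neighbour is compound 3, reached by a change at the carbonyl carbon, a 2.0-fold lower number from compound 1 to compound 3 (0.30 log units; within the scatter); its furthest is compound 2, reached by a change on the aromatic carbon, a 3.4-fold higher number from compound 1 to compound 2 (0.53 log units; beyond the scatter). The third measured step, a 6.8-fold lower number from compound 2 to compound 3 (0.83 log units; beyond the scatter), also concerns the group on the carbonyl carbon.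

The unmeasured compound 4, `COc1cc(C2CC(=NOC(=O)c3ccccc3O)CC(c3ccc(O)c(OC)c3)N2C)ccc1O`, differs from compound 1 in exactly one place: 2-hydroxyphenyl in place of 4-methoxyphenyl on a carbonyl carbon. Among the measured compounds shown here, the steps that bear on this change are the two that exchange the aryl group on the carbonyl carbon. Of these, the move from compound 1 to compound 3 installed a hydroxyphenyl group in place of 4-methoxyphenyl and gave a lowering that stayed within the scatter, while the move from compound 2 to compound 3 gave a clearer lowering. For the measured compounds named here, compound 4 carries a hydroxyphenyl group as well, though as 2-hydroxyphenyl rather than 3-hydroxyphenyl, and no measured pair tells how the two hydroxyphenyl groups compare. The step from compound 1 to compound 4 in this assay is therefore expected to be small, a 1.5-fold lower number from compound 1 to compound 4 (0.18 log units; within the scatter), and not clearly beyond the scatter. Compound 4 is estimated at 22000 nM, within a range from 8000 nM to 60000 nM.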

Compound 4, half-maximal inhibitory concentration: 15900 nM
Compound 4: middle estimate off by 1.4-fold (0.14 log units), on the high side; the measured number falls inside the stated range.
By their numbers in this assay, from the lowest: compounds 4, 3 and 1 (each within the scatter of the next, the first and the last beyond it); then compound 2.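

In this assay, 2-hydroxyphenyl in place of 3-hydroxyphenyl on the carbonyl carbon gives a 1.0-fold lower number from compound 3 to compound 4 (0.02 log units; within the scatter), so the two hydroxyphenyl groups cannot be told apart at this position. The exchange of 4-methoxyphenyl for a hydroxyphenyl group now gives a 2.1-fold lower number from compound 1 to compound 4 (0.32 log units; beyond the scatter), just past the scatter, whereas the same kind of exchange with 3-hydroxyphenyl stayed within it, and the exchange of 4-chlorophenyl gives a 7.0-fold lower number from compound 2 to compound 4 (0.85 log units; beyond the scatter), so compound 2 stays clearly apart from both hydroxyphenyl compounds while compound 1 remains within the scatter of compound 3 and beyond it only from compound 4. Nothing among the data shown accounts for these steps.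

As far as these compounds go, whether a 4-hydroxyphenyl, an unsubstituted phenyl or an aminophenyl group on the carbonyl carbon would give numbers like those of compound 3 and compound 4 remains open. Also open, from the compounds shown here alone, is how a carboxylic acid on the ring, or a longer chain in place of the aryl group, would fare in this assay.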